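From Ethyl Ester to Acid: An Expected Step

The source may report more compounds than this note shows. Statements on the series, on what has been measured and on what is new or still open speak of the compounds shown alone.

Compound 1, `CCOC(=O)CO/N=C(\C)c1ccc(Sc2cc(F)cc(C3CCOCC3)c2)cc1`, stands at the weak end of the three measured compounds. In a functional assay (blood) for inhibition, with Homo sapiens as the target (on this read-out higher numbers stand for weaker inhibition and lower numbers for stronger inhibition), compound 1 gives 610 nM, the highest of the three numbers. Compound 2, `COC1(c2cc(F)cc(Sc3ccc4c(c3)CC/C4=N\O)c2)CCOCC1`, gives 290 nM in this assay, a lower number that lies beyond the scatter of compound 1. Compound 3, `COC1(c2csc(Sc3ccc4c(c3)OCC/C4=N\O)c2)CCOCC1`, gives 40 nM in this assay, the lowest of the three and the furthest from compound 1. No pair among these three differs in a single place, so they are read only as values side by side.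

Compound 4, `C/C(=N\OCC(=O)O)c1ccc(Sc2cc(F)cc(C3CCOCC3)c2)cc1`, differs from compound 1 in a single place: hydrogen in place of ethyl on an oxygen next to a carbonyl group. Cut one bond further out, the change reads ethoxycarbonyl to carboxy. For the measured compounds named here, no measured pair shows such a change here, so its effect cannot be taken from these data. The account expects a modest step, with the carboxy compound estimated to give a somewhat higher number, an expected step of a 1.5-fold higher number from compound 1 to compound 4 (0.17 log units; within the scatter). Compound 4 is estimated at 900 nM in this assay, with a range from 250 nM to 3000 nM.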

Compound 4, half-maximal inhibitory concentration: 740 nM
The estimate for compound 4 lay 1.2-fold (0.09 log units) above the measured number, and the stated range covers the measured number.
By their numbers in this assay, from the lowest: compound 3; then compound 2; then compounds 1 and 4 (each within the scatter of the next).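

In this assay, for the compounds shown here, the first pair of compounds that differ in one place gives a 1.2-fold higher number from compound 1 to compound 4 (0.08 log units; within the scatter), so ethoxycarbonyl and carboxy cannot be told apart on this read-out. The earlier compounds shown here could only be set side by side, whereas this pair shows that, on this core, hydrogen in place of ethyl on an oxygen next to a carbonyl group makes no difference beyond the scatter. Nothing in the available data gives a reason for this result.

From the compounds shown here alone, whether a methyl ester, a primary amide or a longer chain at this place would also read alike with compound 1 and compound 4 remains open. So does whether ethoxycarbonyl and carboxy would stay equal on a different core, such as that of compound 3.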